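Methyl to Hydrogen on an Aryl Oxygen: an Expected Value

The source may hold more compounds than are shown below. What is called first, only, known or untested is meant among the compounds shown, and "the series" means these compounds.

Measured so far in a functional assay on COLO 205 cells (Homo sapiens) for inhibition, read by sulforhodamine B assay, with a stated time of 48 h; a lower number here means a stronger inhibitor of growth, a higher number a weaker inhibitor of growth:

Compound 1, `COc1cc(C)cc(-c2c(-c3ccnc(-c4ccc(N(C)C)cc4)c3)cnn2CC#N)c1`: 220 nM
Compound 2, `COc1cc(C)cc(-c2nn(CC#N)cc2-c2ccnc(-c3ccc(N(C)C)cc3)c2)c1`: 320 nM

Compound 2 carries the higher of the two numbers, but its gap to compound 1 lies within the usual scatter of this assay, so the two compounds cannot be told apart on these values. Both share the same core and differ only in how the two aryl groups are arranged around it.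

Compound 3, `Cc1cc(O)cc(-c2nn(CC#N)cc2-c2ccnc(-c3ccc(N(C)C)cc3)c2)c1`, has not yet been measured. Compared with compound 2, it shows one change: hydrogen in place of methyl on an oxygen on an aromatic ring. Within the data shown here, nothing among the measured pairs shows this particular change, so there is no step on record to lean on. The expectation is therefore cautious: the step of a 1.1-fold higher number from compound 2 to compound 3 (0.04 log units; within the scatter) is expected to stay close to the scatter, with no strong lean in either direction. Compound 3 is estimated to give 350 nM, with a range from 120 nM to 1000 nM that allows for a modest shift either way.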

Compound 3, concentration for 50% growth inhibition: 1950 nM
Compound 3: middle estimate off by 5.6-fold (0.75 log units), on the low side; the measured number lies above the stated range.
By their numbers in this assay, from the lowest: compounds 1 and 2 (each within the scatter of the next); then compound 3.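

In this assay, among these compounds, replacing methoxy with hydroxy on the aromatic ring gives a 6.1-fold higher number from compound 2 to compound 3 (0.78 log units; beyond the scatter) and is the only step here that stands clear of the scatter. The change is small, since it removes one methyl and leaves a hydrogen on the oxygen, yet it clearly weakens growth inhibition, so this site on the 3-methoxy-5-methylphenyl group is sensitive even to the loss of a single carbon. No measurement of any property of these compounds bears on why the number rises, so the result records an effect without giving its cause.

As far as these compounds go, one pair cannot separate the loss of the methyl from the arrival of the hydrogen on the oxygen, and it remains open how an ethoxy group, with its longer chain on the same oxygen, or an amine in place of the oxygen would compare. Also open, from the compounds shown here alone, is whether the same swap would cost as much on compound 1, where the two aryl groups are arranged differently around the shared core.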